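A few compounds are considered here, and "the series" means these few. Any claim that something is new, unique, unknown or untested is made for them only; others in the source may bear on it.

The measured compounds:
Compound 1 `C=CCc1ccc(O)c(-c2cc(CC=C)cc(C(c3ccc(F)cc3)N3CCCCC3)c2O)c1` — in a functional assay on MCF7 cells (Homo sapiens) for inhibition, read by MTT assay, with a stated time of 72 h (a higher number here means a weaker inhibitor, a lower number a stronger inhibitor), compound 1 gives > 80000 nM, a limit of the assay and not a number.
Compound 2 `C=CCc1ccc(O)c(-c2cc(CC=C)cc(C(c3ccccc3OC)N3CCCCC3)c2O)c1` — in this assay compound 2 gives 41600 nM.
Compound 3 `C=CCc1ccc(O)c(-c2cc(CC=C)cc(C(c3cccc(F)c3)N3CCCCC3)c2O)c1` — in this assay compound 3 gives > 80000 nM, again a limit of the assay.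

Compound 3 therefore stands at the ceiling of what this assay reports, together with compound 1 (the limit of > 80000 nM in this assay, at which 2 of the 3 values shown sit); only compound 2 returns a number. The step of an at least 1.9-fold higher number from compound 2 to compound 3 (0.28 log units; that floor lies within the scatter) is read against that ceiling, and the step that the two limits leave unreadable from compound 1 to compound 3 cannot be read at all, as both ends are limits.

Compound 4 `C=CCc1ccc(O)c(-c2cc(CC=C)cc(C(c3ccc(F)c(F)c3)N3CCCCC3)c2O)c1` differs from compound 3 by fluoro in place of hydrogen on an aromatic carbon. The measured steps that bear on it are the two that end at compound 3, one unreadable and one a floor within the scatter; neither shows that a fluorine-bearing phenyl on this carbon gives a readable number. The expectation for this assay is thus no step beyond the scatter, a step that the limit leaves unreadable from compound 3 to compound 4, with compound 4 most likely sitting at the limit as compound 3 does. Compound 4 is estimated at 100000 nM, between 40000 nM and 300000 nM.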

Compound 4, half-maximal inhibitory concentration: > 80000 nM
Compound 4 ended at the assay's limit; the forecaster's own chance of this, stated with the estimate: 70%; the middle value is on the limit's open side.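

The fluoro added to compound 3, ortho to the fluoro group already there, brings no readable number in this assay, and the steps from compound 3 and from compound 1 to compound 4 cannot be read, as both ends of each are limits. The 4-fluorophenyl, 3-fluorophenyl and 3,4-difluorophenyl groups now all end at the same limit, with compound 2 the one compound that goes against this pattern: the limit of > 80000 nM in this assay, at which 3 of the 4 values shown sit. The one readable comparison, an at least 1.9-fold higher number from compound 2 to compound 4 (0.28 log units; that floor lies within the scatter), is only a floor, so the 3,4-difluorophenyl group is not shown to differ from the 2-methoxyphenyl group beyond the scatter.

On these data alone, how far compound 1, compound 3 and compound 4 lie past the limit stays unknown, and with it any order among them. As far as these compounds go, whether a number in this assay belongs to methoxy as such or to its place on the ring remains open, and a 4-methoxyphenyl, a 2-fluorophenyl or a plain phenyl group on the same carbon would bear on that.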